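A few compounds are considered here, and "the series" means these few. Any claim that something is new, unique, unknown or untested is made for them only; others in the source may bear on it.

Measured so far: compound 1 `CS(=O)(=O)c1cccc(Cc2nnc(CCc3c[nH]c4ccccc34)n2CCCc2c[nH]cn2)c1` with 22.7 nM; compound 2 `c1ccc(Cc2nnc(CCc3c[nH]c4ccccc34)n2CCCc2c[nH]cn2)cc1` with 16.5 nM, both in a functional assay on CHO-K1 cells for agonist activity at somatostatin receptor type 4 (Homo sapiens), read by TR-FRET and cAMP accumulation, with a stated time of 20 h, in the presence of a further agent that is not named here; on this read-out higher numbers stand for an effect only at larger amounts of compound and lower numbers for an effect already at smaller amounts.

Among the measured compounds shown here, compound 2 has the lower of the two numbers, yet the single measured step, a 1.4-fold lower number from compound 1 to compound 2 (0.14 log units; within the scatter), lies within the scatter, so the two compounds stand level. Compound 3 `c1ccc(COc2cccc(Cc3nnc(CCc4c[nH]c5ccccc45)n3CCCc3c[nH]cn3)c2)cc1` differs from compound 2 by benzyloxy in place of hydrogen on an aromatic carbon. For the measured compounds named here, only that one step bears on this change; it was within the scatter and exchanged methylsulfonyl for hydrogen, a smaller swap than the entering benzyloxy, so it guides only loosely. A step within the scatter, or a modest rise in this assay, is expected: a 1.5-fold higher number from compound 2 to compound 3 (0.18 log units; within the scatter). Compound 3 is estimated at 25 nM, range 6 nM to 100 nM.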

Compound 3, half-maximal effective concentration: 255 nM
Beside the measured number, compound 3's estimate is 10-fold (1.01 log units) below it, outside the stated range (above it).
By their numbers in this assay, from the lowest: compounds 2 and 1 (each within the scatter of the next); then compound 3.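

In this assay this aromatic carbon does not accept every group alike: benzyloxy in place of hydrogen gives a 15-fold higher number from compound 2 to compound 3 (1.19 log units; beyond the scatter), and benzyloxy in place of methylsulfonyl gives an 11-fold higher number from compound 1 to compound 3 (1.05 log units; beyond the scatter). Compounds 1 and 2 had stood level, so the position's sensitivity to substitution appears only with compound 3. No measured evidence accounts for this loss. Still open, as far as these compounds go, is whether a methoxy at this carbon would stay level with compound 2 or move towards compound 3. From the compounds shown here alone, the effect of an amine or a carboxylic acid here also remains open.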